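Replacing the Side Chain of Compound 3

A few compounds are considered here, and "the series" means these few. Any claim that something is new, unique, unknown or untested is made for them only; others in the source may bear on it.

In a functional assay on MCF7 cells (Homo sapiens) for cytotoxicity, read by MTT assay, with a stated time of 72 h (a higher number here means a weaker inhibitor, a lower number a stronger inhibitor), compound 1 (`CN1CCN(CCCCn2c3c(c4ccccc42)C(=O)c2c[n+]([O-])c4ccccc4c2C3=O)CC1`) gives 100 nM, compound 2 (`CN1CCN(CCCn2c3c(c4ccccc42)C(=O)c2c[n+]([O-])c4ccccc4c2C3=O)CC1`) gives 220 nM and compound 3 (`CN1CCN(CCCCCCn2c3c(c4ccccc42)C(=O)c2c[n+]([O-])c4ccccc4c2C3=O)CC1`) gives 400 nM. Compound 3 is clearly separated from only one of the other two: the measured steps are a 4.0-fold higher number from compound 1 to compound 3 (0.60 log units; beyond the scatter) and a 1.8-fold higher number from compound 2 to compound 3 (0.26 log units; within the scatter).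

Compound 4 (`O=C1c2c[n+]([O-])c3ccccc3c2C(=O)c2c1c1ccccc1n2CCCN1CCC(O)CC1`) departs from compound 3 by 4-hydroxypiperidin-1-yl in place of 3-(4-methylpiperazin-1-yl)propyl on a saturated chain carbon, three bonds along the chain from an aromatic nitrogen: 4-hydroxypiperidin-1-yl in place of 3-(4-methylpiperazin-1-yl)propyl, on a saturated chain carbon, three bonds along the chain from an aromatic nitrogen.

The closest guide is the step of a 1.8-fold higher number from compound 2 to compound 3 (0.26 log units; within the scatter), which involves the same 3-(4-methylpiperazin-1-yl)propyl at the same place. The other steps, a 2.2-fold higher number from compound 1 to compound 2 (0.34 log units; beyond the scatter) and a 4.0-fold higher number from compound 1 to compound 3 (0.60 log units; beyond the scatter), are modest. Among the measured compounds shown here, no measured compound carries 4-hydroxypiperidin-1-yl, so the effect of that group remains open and the range must stay wide.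

A modest step at most is therefore expected, with no shift beyond the scatter in this assay. The expected step is a 1.3-fold lower number from compound 3 to compound 4 (0.12 log units; within the scatter). Compound 4 is estimated at 300 nM, with an expected range of 100 nM to 900 nM.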

Compound 4, half-maximal inhibitory concentration: 190 nM
For compound 4 the middle estimate is 1.6-fold (0.20 log units) above the measured one; the measured number falls inside the stated range.
By their numbers in this assay, from the lowest: compounds 1, 4, 2 and 3 (each within the scatter of the next, the first and the last beyond it).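

In this assay, the ring at the end of the chain could be exchanged with the chain itself kept: 4-hydroxypiperidin-1-yl in place of 4-methylpiperazin-1-yl gives a 1.2-fold lower number from compound 2 to compound 4 (0.06 log units; within the scatter). The step of a 2.1-fold lower number from compound 3 to compound 4 (0.32 log units; beyond the scatter) changes the chain and the ring together, so it cannot be credited to the ring alone, while a 1.9-fold higher number from compound 1 to compound 4 (0.28 log units; within the scatter) likewise changes both and stays within the scatter. No supporting measurement bears on why these compounds read as they do.

Going by these compounds, the 4-hydroxypiperidin-1-yl group appears here on one chain only, so its behaviour on a longer chain remains open. On these data alone, whether its hydroxyl matters also remains open, a question that a plain piperidine or a morpholine at the chain end would address.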